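Swapping the triazole's amide arm for a 4-methylphenyl group

A few compounds are considered here, and "the series" means these few. Any claim that something is new, unique, unknown or untested is made for them only; others in the source may bear on it.

Of the compounds shown here, three sharing one core have been tested in a functional assay on A549 cells (Homo sapiens) for inhibition, read by MTT assay, with a stated time of 24 h; a lower number here means a stronger inhibitor, a higher number a weaker inhibitor. Compound 1 `CCOC(=O)C1=Cc2ccccc2OC1(OCc1cn(CC(=O)NC2CCCCC2)nn1)C(F)(F)F` carries a cyclohexyl group on its amide nitrogen and gives 9900 nM. Compound 2 `CCOC(=O)C1=Cc2ccccc2OC1(OCc1cn(CC(=O)Nc2ccccc2F)nn1)C(F)(F)F` carries a 2-fluorophenyl group there and gives 50100 nM, a step of a 5.1-fold higher number from compound 1 to compound 2 (0.70 log units; beyond the scatter). Compound 3 `CCOC(=O)C1=Cc2ccccc2OC1(OCc1cn(CC(=O)Nc2cccc(F)c2)nn1)C(F)(F)F` carries a 3-fluorophenyl group and gives > 150000 nM, which is a limit of the assay rather than a number. Compound 3 therefore sits at the limit of > 150000 nM in this assay, at which 1 of the 3 values shown sits, and stands as the weakest of the three, its steps being an at least 15-fold higher number from compound 1 to compound 3 (1.18 log units; beyond the scatter) and an at least 2.9-fold higher number from compound 2 to compound 3 (0.47 log units; beyond the scatter).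

Compound 4 `CCOC(=O)C1=Cc2ccccc2OC1(OCc1cn(-c2ccc(C)cc2)nn1)C(F)(F)F` differs from compound 3 in this way: 4-methylphenyl in place of ((3-fluorophenyl)carbamoyl)methyl on an aromatic nitrogen. Among the measured compounds shown here, none of the measured steps touches the aromatic nitrogen itself; they only vary what hangs on the amide nitrogen, and they show that such variation moves the result by modest to large amounts. The change to compound 4 removes the amide entirely, so the measured steps give only a loose guide. For the measured compounds named here, because compound 3 sits at the limit (the limit of > 150000 nM in this assay, at which 1 of the 3 values shown sits), a move downward is the only direction a number could take. My estimate for compound 4 in this assay is 40000 nM, with a range from 8000 nM to 150000 nM, an expected step of an at least 3.7-fold lower number from compound 3 to compound 4 (0.57 log units; beyond the scatter).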

Compound 4, half-maximal inhibitory concentration: 19700 nM
Estimate against measurement, compound 4: 2.0-fold (0.31 log units) above; measured number inside the range.
By their numbers in this assay, from the lowest: compounds 1 and 4 (each within the scatter of the next); then compound 2. At a limit, above all of these: compound 3.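

In this assay, the amide arm turns out not to be needed for a measurable result at this aromatic nitrogen: replacing it with 4-methylphenyl gives an at least 7.6-fold lower number from compound 3 to compound 4 (0.88 log units; beyond the scatter) and a 2.5-fold lower number from compound 2 to compound 4 (0.41 log units; beyond the scatter), so the change improves on both fluorophenyl amides. Against the cyclohexyl amide, the same change gives a 2.0-fold higher number from compound 1 to compound 4 (0.30 log units; within the scatter), so compound 4, whose new group has no hydrogen-bond donor or acceptor, cannot be told apart from compound 1, and the amide's donor and acceptor are not required for a number in this range. The value of compound 3 is a limit of the assay and not a number, so its step has only a lower bound: the limit of > 150000 nM in this assay, at which 1 of the 4 values shown sits.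

The compounds shown leave open whether the 4-methylphenyl group itself matters or whether a plain phenyl, a 4-methoxyphenyl or a benzyl group on the same nitrogen would serve equally well. They also leave open how an amide arm carrying 4-methylphenyl on its own nitrogen would compare, which would separate the effect of the group from the effect of losing the amide.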